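Aryl variation on the shared core: expectation for compound 4

The compounds below may be only part of what the source reports. "The series", "measured", "known", "first", "only" and "open" are said of these compounds alone.

Compound 1 `CCCS(=O)(=O)Nc1ccc(F)c(C(=O)c2n[nH]c3ncc(-c4cccc(F)c4)cc23)c1F` is the reference point of this small set. Going by the values given here, in an assay for binding affinity to dual specificity mitogen-activated protein kinase kinase 4 (Homo sapiens), read by KINOMEscan, tested at 100 nM (on this read-out lower numbers stand for a stronger effect and higher numbers for a weaker effect at the one concentration tested), compound 1 gives 8.2%, the highest of the three numbers so far, though the two others sit within the scatter of it. Compound 2 `CCCS(=O)(=O)Nc1ccc(F)c(C(=O)c2n[nH]c3ncc(-c4cccc(OC)c4)cc23)c1F` gives 6.3% in this assay, a change of a number 1.9 percentage points lower from compound 1 to compound 2 (within the scatter). Compound 3 `CCCS(=O)(=O)Nc1ccc(F)c(C(=O)c2n[nH]c3ncc(-c4ccc(N(C)C)cc4)cc23)c1F` gives 2.5% in this assay, a change of a number 5.7 percentage points lower from compound 1 to compound 3 (within the scatter); between the two aryl variants the step is a number 3.8 percentage points lower from compound 2 to compound 3 (within the scatter). None of these three steps leaves the scatter, so the aryl ring on the shared core has so far made no detectable difference.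

Compound 4 `CCCS(=O)(=O)Nc1ccc(F)c(C(=O)c2n[nH]c3ncc(-c4ccc(C(C)(C)C)cc4)cc23)c1F` is not yet measured. It differs from compound 1 in one place: 4-(tert-butyl)phenyl in place of 3-fluorophenyl on an aromatic carbon. Among the compounds with values here, the steps that bear on it are the aryl exchanges from compound 1 to compound 2 and from compound 1 to compound 3, both small and within the scatter. The expectation is therefore that compound 4 also stays close to compound 1 in this assay, with a step of a number 2.2 percentage points lower from compound 1 to compound 4 (within the scatter), meaning none beyond the scatter. Compound 4 is estimated at 6%, with a range from 1% to 14%.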

Compound 4, a percentage reported as activity, at one concentration (the size of the read-out at that concentration, not a potency): 46%
Beside the measured number, compound 4's estimate is 40 percentage points below it; the whole stated range lies below it.
By their numbers in this assay, from the lowest: compounds 3, 2 and 1 (each within the scatter of the next); then compound 4.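

Working notes: the aryl group at this position is not indifferent after all. In this assay, going by these compounds alone, 4-(tert-butyl)phenyl in place of 3-fluorophenyl gives a number 37.8 percentage points higher from compound 1 to compound 4 (beyond the scatter), and in place of 3-methoxyphenyl it gives a number 39.7 percentage points higher from compound 2 to compound 4 (beyond the scatter); these are the first aryl exchanges in the set to leave the scatter. The closest comparison is tert-butyl in place of dimethylamino on the same phenyl ring, a number 43.5 percentage points higher from compound 3 to compound 4 (beyond the scatter), which shows that the outcome depends on the group the ring carries, so a 4-substituted phenyl as such does not account for the change, and no measurement at hand gives a reason for this step.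

Going by these compounds, it remains open whether methyl or isopropyl on the same phenyl ring already raises the number or whether tert-butyl alone does so, and whether a morpholine or a carboxylic acid there keeps the number low, as dimethylamino does in compound 3. On these data alone, the read-out comes from one concentration, so what the step means as a difference in potency also stays open.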